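The source may hold more compounds than are shown below. What is called first, only, known or untested is meant among the compounds shown, and "the series" means these compounds.

Measured compounds: compound 1 `COc1cc(N(C)CCN(C)C)c(NC(=O)/C=C\C(C)C)cc1Nc1nccc(-c2cn(C)c3ccccc23)n1` with 4390 nM; compound 2 `CC/C=C\C(=O)Nc1cc(Nc2nccc(-c3cn(C)c4ccccc34)n2)c(OC)cc1N(C)CCN(C)C` with 6670 nM; compound 3 `CC/C=C\C(=O)Nc1cc(Nc2nc(C)cc(-c3cn(C)c4ccc(F)cc34)n2)c(OC)cc1N(C)CCN(C)C` with 11000 nM.

All three were tested in a functional assay on HepG2 cells (Homo sapiens) for antiproliferative activity, read by MTT assay, with a stated time of 72 h; on this read-out lower numbers stand for stronger inhibition and higher numbers for weaker inhibition. Compound 1 differs from compound 2 by methyl in place of hydrogen on a saturated chain carbon bound to a double-bonded chain carbon and a saturated chain carbon, and that step gave a 1.5-fold lower number from compound 2 to compound 1 (0.18 log units; within the scatter). Compound 3 carries another core; how its core differs from the core of compound 2 is not broken down here. In this assay compound 3 gives 11000 nM, against 6670 nM for compound 2 and 4390 nM for compound 1.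

Compound 4 `COc1cc(N(C)CCN(C)C)c(NC(=O)/C=C\C(C)C)cc1Nc1nc(C)cc(-c2cn(C)c3ccc(F)cc23)n1` has not yet been measured. It differs from compound 3 by methyl in place of hydrogen on a saturated chain carbon bound to a double-bonded chain carbon and a saturated chain carbon, the same change as from compound 2 to compound 1. The expected step in this assay is a 1.5-fold lower number from compound 3 to compound 4 (0.17 log units; within the scatter), resting on a 1.5-fold lower number from compound 2 to compound 1 (0.18 log units; within the scatter). Compound 4 is therefore estimated at 7500 nM, between 3500 nM and 16000 nM.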

Compound 4, half-maximal inhibitory concentration: 14000 nM
Beside the measured number, compound 4's estimate is 1.9-fold (0.27 log units) below it, and the stated range covers the measured number.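

In this assay, going from but-1-en-1-yl to 3-methylbut-1-en-1-yl on the core of compound 3 gave a 1.3-fold higher number from compound 3 to compound 4 (0.10 log units; within the scatter). The two cores cannot be told apart for this change, since the steps on them run in opposite directions yet remain close: the same change on two cores in this assay, a 1.5-fold lower number (0.18 log units; within the scatter) from compound 2 to compound 1 and a 1.3-fold higher number (0.10 log units; within the scatter) from compound 3 to compound 4, 1.9-fold (0.29 log units) apart, within the scatter of two such steps. This shows that the change moved the number by no more than the scatter on either core, but it does not show that the change acts identically on both, nor does it establish a gain or a loss on either.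

The compounds shown leave open whether a longer chain or an amine at this end of the amide would give a step that can be read. They also leave open how the change would behave on any further core.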